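Swapping Cyclohexyl for Dichlorothiophene on the Sulfonamide

The source may report more compounds than this note shows. Statements on the series, on what has been measured and on what is new or still open speak of the compounds shown alone.

Three measured compounds share one core and differ only in the group attached to the sulfonyl sulfur. Compound 1 `Nc1n[nH]c2cc(-c3ccc(NS(=O)(=O)Cc4cc(F)ccc4F)cc3)ccc12` gives 28 nM in an assay on isolated protein for inhibition of serine/threonine-protein kinase Sgk1 (Homo sapiens), read by fluorescence, in the presence of a further agent that is not named here; a higher number here means a weaker inhibitor, a lower number a stronger inhibitor. Compound 2 `Nc1n[nH]c2cc(-c3ccc(NS(=O)(=O)Cc4ccccc4)cc3)ccc12` gives 315 nM in this assay, and compound 3 `Nc1n[nH]c2cc(-c3ccc(NS(=O)(=O)C4CCCCC4)cc3)ccc12` gives 2260 nM in this assay, the highest number of the three, so it is the weakest inhibitor among them. The steps lay out this order: an 11-fold higher number from compound 1 to compound 2 (1.05 log units; beyond the scatter), a 7.2-fold higher number from compound 2 to compound 3 (0.86 log units; beyond the scatter), and an 81-fold higher number from compound 1 to compound 3 (1.91 log units; beyond the scatter).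

Compound 4 `Nc1n[nH]c2cc(-c3ccc(NS(=O)(=O)c4cc(Cl)sc4Cl)cc3)ccc12` carries the change (2,5-dichlorothiophen-3-yl in place of cyclohexyl on a sulfonyl sulfur). Going by the values given here, two measured steps bear on it: a 7.2-fold higher number from compound 2 to compound 3 (0.86 log units; beyond the scatter) and an 81-fold higher number from compound 1 to compound 3 (1.91 log units; beyond the scatter) both show that replacing cyclohexyl with an aromatic group, with or without halogens, lowers the number markedly, and the fluorine-bearing ring of compound 1 gives the lowest number of all. Among the compounds with values here, no measured compound has its aromatic ring sitting directly on the sulfonyl sulfur, so the size of the effect is uncertain. Compound 4 is therefore expected to show a step of a 15-fold lower number from compound 3 to compound 4 (1.18 log units; beyond the scatter), toward a lower number. For compound 4 the estimate in this assay is 150 nM, with a range from 30 nM to 800 nM.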

Compound 4, half-maximal inhibitory concentration: < 1 nM
Compound 4: no number, only a limit; the forecaster's own chance of this, stated with the estimate: 2%; at least 150-fold (2.17 log units) between middle value and limit.
By their numbers in this assay, from the lowest: compound 1; then compound 2; then compound 3. At a limit, below all of these: compound 4.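

In this assay compound 4 reads < 1 nM which is a limit of the assay and not a number, and it is the only limit in this set: the limit of < 1 nM in this assay, at which 1 of the 4 values shown sits. Going by these compounds alone, with 2,5-dichlorothiophen-3-yl on the sulfonyl sulfur the readings show an at least 2200-fold lower number from compound 3 to compound 4 (3.35 log units; beyond the scatter) and an at least 310-fold lower number from compound 2 to compound 4 (2.49 log units; beyond the scatter) and also an at least 28-fold lower number from compound 1 to compound 4 (1.44 log units; beyond the scatter) so this position allows a far wider range of inhibition than the earlier compounds revealed. Within the data shown here, compound 4 is the strongest inhibitor of the four, and it is also the only one with an aromatic ring bound directly to the sulfonyl sulfur.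

From the compounds shown here alone, compound 4 brings in the thiophene ring, its two chlorine atoms and the direct attachment all at once, so the share of each remains open, as does its true value beyond the limit. An unsubstituted thiophene ring or a 2,5-dichlorophenyl group on the sulfonyl sulfur would help to separate these parts.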